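Ring substituent series on the pyrrolidinylmethoxy-pyridine core

The source may hold more compounds than are shown below. What is called first, only, known or untested is meant among the compounds shown, and "the series" means these compounds.

Measured so far:
compound 1, `CN1CCC[C@H]1COc1cncc(Br)c1`, gives 0.27 nM in an assay on membranes from brain for displacement of a labelled ligand from Neuronal acetylcholine receptor; alpha4/beta2 (Rattus norvegicus); on this read-out higher numbers stand for weaker inhibition and lower numbers for stronger inhibition.
compound 2, `CCCc1cncc(OC[C@@H]2CCCN2C)c1`, gives 0.12 nM in this assay.

Compound 2 holds the lowest of the two numbers; its nearest neighbour is compound 1, and the step of a 2.3-fold lower number from compound 1 to compound 2 (0.35 log units; beyond the scatter) is beyond the scatter.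

Compound 3, `CCCCCCc1cncc(OC[C@@H]2CCCN2C)c1`, is not yet measured. It differs from compound 2 by propyl in place of hydrogen on a saturated chain carbon, three bonds along the chain from an aromatic carbon: the same difference, cut one bond further out, reads propyl to hexyl.

For the measured compounds named here, only one step is known, a 2.3-fold lower number from compound 1 to compound 2 (0.35 log units; beyond the scatter), a modest lowering; it exchanges one ring substituent for another and does not probe a lengthening of the chain. Going by the values given here, no measured pair shows what extending the chain does. The expectation for compound 3 in this assay is therefore a small change, a 2.5-fold higher number from compound 2 to compound 3 (0.40 log units; beyond the scatter), with wide uncertainty in either direction. Compound 3 is estimated at 0.3 nM, range 0.08 nM to 1.2 nM.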

Compound 3, inhibition constant: 0.32 nM
For compound 3 the middle estimate is 1.1-fold (0.03 log units) below the measured one; measured number inside the range.
By their numbers in this assay, from the lowest: compound 2; then compounds 1 and 3 (each within the scatter of the next).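

Extending the chain from propyl to hexyl gives the first reading of chain length at this position in this assay: a 2.7-fold higher number from compound 2 to compound 3 (0.43 log units; beyond the scatter), a modest weakening of inhibition. Hexyl in place of bromo gives a 1.2-fold higher number from compound 1 to compound 3 (0.07 log units; within the scatter), so on this read-out compound 3 and compound 1 cannot be told apart, and the added chain length does not carry compound 3 out of the scatter of compound 1. Nothing available explains why the longer chain gives a higher number than propyl.

From the compounds shown here alone, whether butyl and pentyl fall on a smooth course between propyl and hexyl, and whether an octyl chain moves the number further, remains open. Also open, going by these compounds, is how a chain ending in a hydroxyl group or an amine, or a phenyl ring in place of the chain, would read in this assay.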